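Compound 3: 4-methylphenyl in place of 5-methylpyridin-2-yl

The source may report more compounds than this note shows. Statements on the series, on what has been measured and on what is new or still open speak of the compounds shown alone.

Measured so far:
Compound 1, `O=C1NC(=O)C(Cc2ccc(Oc3ccc(Cl)cn3)cc2)S1`: 1870 nM
Compound 2, `Cc1ccc(Oc2ccc(CC3SC(=O)NC3=O)cc2)nc1`: 4470 nM

Both compounds were tested in a functional assay for agonist activity at Free fatty acid receptor 1 (Homo sapiens), read by FLIPR, in the presence of a further agent that is not named here; on this read-out lower numbers stand for an effect already at smaller amounts and higher numbers for an effect only at larger amounts of compound. In this assay compound 1 gives 1870 nM, and compound 2 gives 4470 nM. Going by the values given here, compound 2 therefore stands highest of the two numbers, with compound 1 as its only neighbour; the one measured step, a 2.4-fold higher number from compound 1 to compound 2 (0.38 log units; beyond the scatter), is the whole of what is known about how the numbers move.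

Compound 3, `Cc1ccc(Oc2ccc(CC3SC(=O)NC3=O)cc2)cc1`, has not been measured. It differs from compound 2 in one place: 4-methylphenyl in place of 5-methylpyridin-2-yl on an oxygen on an aromatic ring. Among the compounds with values here, no measured step bears on this kind of change; the only step known concerns a methyl in place of a chloro, which is a different exchange, so nothing in the numbers points one way or the other. Without such a precedent, the expected step of no change at the digits printed from compound 2 to compound 3 (within the scatter) is one of no change beyond the scatter. Compound 3 is accordingly estimated at 4470 nM in this assay, with a range from 1500 nM to 13000 nM.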

Compound 3, half-maximal effective concentration: 547 nM
The estimate for compound 3 lay 8.2-fold (0.91 log units) above the measured number; measured number outside the range, below it.
By their numbers in this assay, from the lowest: compound 3; then compound 1; then compound 2.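

In this assay, the exchange at this place, on an oxygen on an aromatic ring, gives an 8.2-fold lower number from compound 2 to compound 3 (0.91 log units; beyond the scatter), and compound 3 has the lowest number of the three, since the other listed step is a 3.4-fold lower number from compound 1 to compound 3 (0.53 log units; beyond the scatter). The earlier compounds shown here varied only the group carried on the pyridine ring, whereas this result shows that the number also responds to the ring itself: a ring of carbon only, with no hydrogen-bond acceptor, replaces a ring with one nitrogen and one hydrogen-bond acceptor, with the same count of heavy atoms in the 4-methylphenyl and the 5-methylpyridin-2-yl. No measurement is at hand that explains why the number moves with this exchange.

The compounds shown leave open whether the ring and its group act independently, as no compound pairs chloro with the ring of carbon only, so the effect of chloro in place of methyl on that ring cannot be told from the step seen on the pyridine ring. Also open, on these data alone, is how a methoxy group, an amine or a carboxylic acid in place of the methyl would fare on the 4-methylphenyl ring.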